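The source may report more compounds than this note shows. Statements on the series, on what has been measured and on what is new or still open speak of the compounds shown alone.

In a functional assay on SK-MEL-147 cells (Homo sapiens) for cytotoxicity, read by MTT assay, with a stated time of 24 h (on this read-out lower numbers stand for an effect already at smaller amounts and higher numbers for an effect only at larger amounts of compound), compound 1 `CCOC(=O)c1cc([Se]c2ccccc2)c2cc(Br)ccc2n1` gives 12400 nM while compound 2 `CCOC(=O)c1cc([Se]c2ccc3cc(OC)ccc3c2)c2cc(OC)ccc2n1` gives 30800 nM and compound 3 `CCOC(=O)c1cc([Te]c2ccccc2)c2cc(OC)ccc2n1` gives 128000 nM on the same read-out. Compound 2 thus stands second highest of the three, and its gaps to both of the others lie beyond the scatter. The change from it to compound 4 `CCOC(=O)c1cc([Se]c2ccc3ccccc3c2)c2cc(OC)ccc2n1` is hydrogen in place of methoxy on an aromatic carbon with hydrogen in place of methoxy on an aromatic carbon. Among the measured compounds shown here, no measured pair shows this change on its own, so in this assay only a small shift toward a lower number is expected, possibly none beyond the scatter. The estimated move is a 1.4-fold lower number from compound 2 to compound 4 (0.15 log units; within the scatter) and it remains uncertain. For compound 4 the expected value is 22000 nM with an estimated range from 8000 nM to 60000 nM as the likely span.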

Compound 4, half-maximal effective concentration: 32200 nM
For compound 4 the middle estimate is 1.5-fold (0.17 log units) below the measured one; measured number inside the range.
By their numbers in this assay, from the lowest: compound 1; then compounds 2 and 4 (each within the scatter of the next); then compound 3.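

In this assay the first pair differing in one place reads as a 1.0-fold higher number from compound 2 to compound 4 (0.02 log units; within the scatter), so compound 2 and compound 4 cannot be told apart with hydrogen in place of methoxy on this aromatic carbon. At this position, in this one pair, the methoxy group therefore makes no difference beyond the scatter. Nothing available explains this result. As far as these compounds go, it remains open whether an amine, a hydroxyl group or a longer chain such as butoxy on this carbon would give a number set apart from these two. From the compounds shown here alone, whether the methoxy group elsewhere on the shared core can be exchanged in the same way also remains open.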